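The source may report more compounds than this note shows. Statements on the series, on what has been measured and on what is new or still open speak of the compounds shown alone.

Measured so far:
- compound 1, `CSN1C(=O)CC1CC/C=C/C(=O)Nc1ccccc1`: 10000 nM
- compound 2, `CC1=C(/C=C/C(C)=C/CNC(=O)/C=C2/CC(=O)N2)C(C)(C)CCC1`: 38000 nM

In a functional assay on SH-SY5Y cells (Homo sapiens) for cytotoxicity, read by MTT assay, with a stated time of 96 h (on this read-out lower numbers stand for stronger inhibition and higher numbers for weaker inhibition), compound 2 gives 38000 nM, the highest of the two numbers. Compound 1 gives 10000 nM, a lower number that lies beyond the usual scatter. Compound 3, `CC1=C(/C=C/C(C)=C\CNC(=O)/C=C2/CC(=O)N2)C(C)(C)CCC1`, has not yet been measured. Compared with compound 2, (the two compounds have the same atoms and bonds and differ only in configuration as drawn: 1 of 3 stereo elements differ; a double bond is drawn E in compound 2 and Z in compound 3). Among the compounds with values here, no measured pair differs only in such a geometry, so no direction is known from the data; the step is expected to stay within the usual scatter. Compound 3 is therefore expected near 38000 nM, in a range from 15000 nM to 100000 nM, and the expected step from compound 2 to compound 3 is no change at the digits printed from compound 2 to compound 3 (within the scatter).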

Compound 3, half-maximal inhibitory concentration: 35000 nM
For compound 3 the middle estimate is 1.1-fold (0.04 log units) above the measured one, and the stated range covers the measured number.
By their numbers in this assay, from the lowest: compound 1; then compounds 3 and 2 (each within the scatter of the next).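

In this assay, within the data shown here, the pair gives the first reading of double-bond geometry: a 1.1-fold lower number from compound 2 to compound 3 (0.04 log units; within the scatter). Drawing this double bond Z rather than E therefore leaves compound 3 indistinguishable from compound 2 on this read-out. The comparison is a clean one, since a single feature separates the pair: the fact that compounds 2 and 3 differ only in the configuration as drawn

The compounds shown leave open whether the geometry of the other double bonds matters equally. They also leave open whether an amine or a carboxylic acid on the shared core would shift the number beyond the scatter.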